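The source may report more compounds than this note shows. Statements on the series, on what has been measured and on what is new or still open speak of the compounds shown alone.

Working notes on the series: in a physicochemical assay for solubility, read by HPLC, in phosphate buffer, measured as kinetic solubility, at pH 7.4 (a lower number here means a less soluble compound, a higher number a more soluble compound), compound 1 `CCC(=O)c1ccn(-c2ccc(S(N)(=O)=O)cc2)c1C` gives 100000 nM, compound 2 `CCC(=O)c1cc(-c2ccc(F)cc2)n(-c2ccc(S(N)(=O)=O)cc2)c1C` gives 29300 nM, and compound 3 `CCC(=O)c1cc(-c2ccc(OC)cc2)n(-c2ccc(S(N)(=O)=O)cc2)c1C` gives 12800 nM, the lowest of the three numbers. Compound 4 `CCC(=O)c1cc(-c2ccc(C)cc2)n(-c2ccc(S(N)(=O)=O)cc2)c1C` is unmeasured and differs from compound 3 by methyl in place of methoxy on an aromatic carbon, with methyl in place of methoxy, para to a large group. The closest evidence is the modest 2.3-fold lower number from compound 2 to compound 3 (0.36 log units; beyond the scatter), at the same place. The modest 3.4-fold lower number from compound 1 to compound 2 (0.53 log units; beyond the scatter) and a 7.8-fold lower number from compound 1 to compound 3 (0.89 log units; beyond the scatter) concern adding the whole substituted phenyl group. Among the measured compounds shown here, no methyl analogue has been measured, so only a small upward move is expected, with no step beyond the scatter. The expected step is a 1.2-fold higher number from compound 3 to compound 4 (0.07 log units; within the scatter). For compound 4 the estimate is 15000 nM, with an expected range of 7500 nM to 30000 nM.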

Compound 4, solubility: 1000 nM
Estimate against measurement, compound 4: 15-fold (1.18 log units) above, and the stated range ends above it.
By their numbers in this assay, from the lowest: compound 4; then compound 3; then compound 2; then compound 1.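

In this assay, among the compounds shown here, the group at this place, para to a large group, can move the number far more than the earlier compounds showed: a 13-fold lower number from compound 3 to compound 4 (1.11 log units; beyond the scatter) is a large step for methyl in place of methoxy. The other two steps, a 29-fold lower number from compound 2 to compound 4 (1.47 log units; beyond the scatter) for methyl in place of fluoro and a 100-fold lower number from compound 1 to compound 4 (2.00 log units; beyond the scatter) for 4-methylphenyl in place of hydrogen, are also large and leave compound 4 lowest of the four. Nothing available accounts for this drop.

The compounds shown leave open whether the low number is particular to methyl or is shared by ethyl or chloro at this place. As far as these compounds go, whether an amine there would raise the number also remains open.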